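The source may hold more compounds than are shown below. What is called first, only, known or untested is meant among the compounds shown, and "the series" means these compounds.

Compound 1 `CC(C)NC(=O)CC(c1ccc(-c2ccc3cccc(F)c3c2)[nH]c1=O)C(C)C` gives 5.8 nM in an assay on CHO cells for displacement of a labelled ligand from prostaglandin E2 receptor EP3 subtype (Homo sapiens), read by radioligand binding; a lower number here means a stronger inhibitor, a higher number a weaker inhibitor. Compound 2 `CC(C)C(Nc1nccs1)c1ccc(-c2ccc3cccc(F)c3c2)[nH]c1=O` gives 9.4 nM in this assay. Compound 3 `CC(C)C(/C=C1\CCNC1=O)c1ccc(-c2ccc3cccc(F)c3c2)[nH]c1=O` gives 2.2 nM in this assay.

Compound 3 stands lowest of the three numbers, with a modest step of a 2.6-fold lower number from compound 1 to compound 3 (0.42 log units; beyond the scatter) and a modest step of a 4.3-fold lower number from compound 2 to compound 3 (0.63 log units; beyond the scatter), both beyond the scatter. Compound 4 `CC(C)C(c1ccc(-c2ccc3cccc(F)c3c2)[nH]c1=O)N1CCN/C1=N\C#N` differs from compound 3 at the same position: a group of 8 heavy atoms (4 carbon, 4 nitrogen; one five-membered non-aromatic ring with 2 hetero atoms) in place of a group of 7 heavy atoms (5 carbon, 1 nitrogen, 1 oxygen; one five-membered non-aromatic ring with 1 hetero atom), on a saturated chain carbon bound to an aromatic carbon and a saturated chain carbon. The two steps that bear on this exchange are those from compound 1 and compound 2 into compound 3, both modest and both favouring the group that compound 3 carries. With that group leaving and a new ring group entering, a modest rise in the number is expected, a 2.5-fold higher number from compound 3 to compound 4 (0.40 log units; beyond the scatter). Compound 4 is therefore estimated at 5.5 nM, within a range from 1.8 nM to 17 nM.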

Compound 4, inhibition constant: 23 nM
Estimate against measurement, compound 4: 4.2-fold (0.62 log units) below; the measured number lies above the stated range.
By their numbers in this assay, from the lowest: compound 3; then compounds 1 and 2 (each within the scatter of the next); then compound 4.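

Within the data shown here, the ring group of compound 4 brings the first large step at this saturated chain carbon (a 10-fold higher number from compound 3 to compound 4 (1.02 log units; beyond the scatter)). It also falls behind the thiazolylamino group and the open isopropylcarbamoylmethyl chain (a 2.4-fold higher number from compound 2 to compound 4 (0.39 log units; beyond the scatter); a 4.0-fold higher number from compound 1 to compound 4 (0.60 log units; beyond the scatter)). Compound 3 and compound 4 both carry a five-membered non-aromatic ring here, so such a ring alone does not keep the number low.

On these data alone, whether the ring of compound 4 with a carbonyl in place of its nitrile-bearing group would recover the lost ground stays open, as does the outcome with a plain amine at this carbon. No measurement given here accounts for these steps.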